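The source may hold more compounds than are shown below. What is called first, only, known or untested is meant among the compounds shown, and "the series" means these compounds.

Values in a functional assay on Jurkat cells (Homo sapiens); on this read-out higher numbers stand for weaker inhibition and lower numbers for stronger inhibition:
- compound 1 `CC(C)[C@H](NC(=O)COc1cccc2ccccc12)C(=O)N[C@@H](CC(=O)O)C(=O)COC(=O)c1c(Cl)cccc1Cl`: 10600 nM
- compound 2 `CC(C)[C@H](NC(=O)COc1cccc2ccccc12)C(=O)N[C@@H](CC(=O)O)C(=O)COc1ccccc1`: 14000 nM
- compound 3 `CC(C)[C@H](NC(=O)COc1cccc2ccccc12)C(=O)N[C@@H](CC(=O)O)C(=O)COc1cc(C(F)(F)F)cc(C(F)(F)F)c1`: > 100000 nM
- compound 4 `CC(C)[C@H](NC(=O)COc1cccc2ccccc12)C(=O)N[C@@H](CC(=O)O)C(=O)COc1ccc(Oc2ccccc2)cc1`: not yet measured

Compound 2, at 14000 nM, stands level with compound 1 and has no other numerical neighbour in the series. The measured step is a 1.3-fold higher number from compound 1 to compound 2 (0.12 log units; within the scatter). Compound 3 reports only > 100000 nM, which is a limit of the assay and not a number.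

Compound 4 differs from compound 2 by a single change, phenoxy in place of hydrogen on an aromatic carbon, para to a large group. Among the compounds with values here, no measured step tests this substitution directly. Within the data shown here, the one numerical step, a 1.3-fold higher number from compound 1 to compound 2 (0.12 log units; within the scatter), concerns a different exchange on the same oxygen, and it shows that compound 1 and compound 2 cannot be told apart in this assay. Among the measured compounds shown here, compound 3 is the only compound with substituents on the phenyl ring, and its > 100000 nM is a limit, so it gives a direction for the expectation but no size. A moderate move towards weaker inhibition is therefore expected, with a wide margin that includes no change beyond the scatter. The estimated step is a 2.1-fold higher number from compound 2 to compound 4 (0.33 log units; beyond the scatter). For compound 4 the expected value is 30000 nM, with an estimated range of 8000 nM to 100000 nM.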

Compound 4, half-maximal inhibitory concentration: 12700 nM
The estimate for compound 4 lay 2.4-fold (0.37 log units) above the measured number, within the range that was stated.
By their numbers in this assay, from the lowest: compounds 1, 4 and 2 (each within the scatter of the next). At a limit, above all of these: compound 3.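

In this assay, phenoxy in place of hydrogen on an aromatic carbon, para to a large group, gives a 1.1-fold lower number from compound 2 to compound 4 (0.04 log units; within the scatter). Within the data shown here, this is the first readable step on the phenyl ring itself, and it shows that this carbon can carry a phenoxy group of 7 heavy atoms, with its six-membered aromatic ring, without a number that can be told apart from that of the unsubstituted ring. Substitution of the phenyl ring is therefore not tied in itself to the result for compound 3, which remains a limit of the assay and not a number: the limit of > 100000 nM in this assay, at which 1 of the 4 values shown sits.

On these data alone, whether the same flat result holds for other groups on this aromatic carbon stays open, for example an amine, a carboxylic acid, a single trifluoromethyl or a benzyloxy group with its longer link to the outer ring. The compounds shown also leave open whether any group at this carbon can move the number beyond the scatter, and what a single trifluoromethyl group contributes to the limit seen for compound 3.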